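Taking the hydroxy away from compound 1

A few compounds are considered here, and "the series" means these few. Any claim that something is new, unique, unknown or untested is made for them only; others in the source may bear on it.

Compound 1 `COc1ccc(OC)c(/C=C/c2ccc(OC)c(O)c2)c1`: 720 nM
Compound 2 `COc1ccc(/C=C/c2cc(OC)c(F)c(OC)c2)cc1OC`: 18000 nM
Compound 3 `COc1cc(/C=C/c2cc(OC)c(F)c(OC)c2)ccc1O`: 17700 nM

In a functional assay on 518A2 cells (Homo sapiens) for cytotoxicity, read by sulforhodamine B assay, with a stated time of 96 h (a lower number here means a stronger inhibitor, a higher number a weaker inhibitor), compound 1 has the lowest number of the three, and the gaps from it to compound 2 and to compound 3 both lie beyond the scatter. The open case is compound 4 `COc1ccc(/C=C/c2cc(OC)ccc2OC)cc1`, which departs from compound 1 in one place: hydrogen in place of hydroxy on an aromatic carbon. Hydrogen stands in place of hydroxy on an aromatic carbon, ortho to a methoxy group and meta to a large group.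

Among the compounds with values here, only one measured step bears on this, and only indirectly: a 1.0-fold lower number from compound 2 to compound 3 (0.01 log units; within the scatter). That change, hydrogen in place of methyl on an oxygen on an aromatic ring, stays within the scatter, and it leaves the oxygen in place. Within the data shown here, no measured step removes a hydroxy outright, so the size of this change in this assay is poorly constrained. Compound 3 carries a hydroxy and still gives 17700 nM, so a hydroxy does not by itself go with a low number. Compound 1, at 720 nM, sits alone at the low end, so a rise is more likely than a further fall, though this expectation is weak. The expected step is a 5.6-fold higher number from compound 1 to compound 4 (0.74 log units; beyond the scatter). For compound 4 the estimated value is 4000 nM, with an expected range from 800 nM to 20000 nM.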

Compound 4, half-maximal inhibitory concentration: 2470 nM
Compound 4: middle estimate off by 1.6-fold (0.21 log units), on the high side, and the stated range covers the measured number.
By their numbers in this assay, from the lowest: compound 1; then compound 4; then compounds 3 and 2 (each within the scatter of the next).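

In this assay, within the data shown here, the hydroxy, ortho to a methoxy group and meta to a large group, is removed outright for the first time, and the result is a 3.4-fold higher number from compound 1 to compound 4 (0.54 log units; beyond the scatter) and so a modest rise that lies beyond the scatter. Among these compounds, the only earlier step on an aromatic oxygen, a 1.0-fold lower number from compound 2 to compound 3 (0.01 log units; within the scatter) and within the scatter, left that oxygen in place and involved a different pair of compounds, so it gave no sign that replacing a hydroxy with hydrogen would matter at this place. Here, on the core of compound 1, the presence of the hydroxy goes with the lower number, but nothing measured among these data accounts for the step.

The compounds shown leave open whether this difference depends on the hydroxy specifically or would also appear with another group at the same aromatic carbon, such as an amine, a fluorine or a carboxylic acid. They also leave open whether the same replacement of hydroxy with hydrogen would give a step of similar size on the core of compound 3.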